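The source may hold more compounds than are shown below. What is called first, only, known or untested is meant among the compounds shown, and "the series" means these compounds.

Among the measured compounds shown here, in a functional assay on HeLa cells (Homo sapiens) for antiproliferative activity, read by MTT assay, with a stated time of 48 h (on this read-out lower numbers stand for stronger inhibition and higher numbers for weaker inhibition), compound 2 `O=C(/C=C/c1ccccc1)Nc1cc2c(Nc3ccc(Cl)c(Cl)c3)ncnc2s1` gives 430 nM as the lower of the two numbers measured so far, while compound 1 `O=C(/C=C/c1ccc(O)cc1)Nc1cc2c(Nc3ccc(Cl)c(Cl)c3)ncnc2s1` gives 24800 nM as the higher. Compound 3 `C#Cc1cccc(Nc2ncnc3sc(NC(=O)/C=C/c4ccccc4)cc23)c1` keeps the rest of compound 2 and alters one group, and 3-ethynylphenyl in place of 3,4-dichlorophenyl on a nitrogen on an aromatic ring sets out that difference: 3-ethynylphenyl in place of 3,4-dichlorophenyl on a nitrogen on an aromatic ring. For the measured compounds named here, the only measured step of a 58-fold lower number from compound 1 to compound 2 (1.76 log units; beyond the scatter) is large, but it concerns hydrogen in place of hydroxy on an aromatic carbon and does not touch this group. Going by the values given here, no measured pair varies the group on the nitrogen, and the data therefore offer no firm size or direction for this change. The expected change a 1.4-fold higher number from compound 2 to compound 3 (0.14 log units; within the scatter) is small, with no step beyond the scatter foreseen in this assay and with wide uncertainty. For compound 3 the estimated value is 600 nM with an expected range from 120 nM to 3000 nM for a measurement.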

Compound 3, half-maximal inhibitory concentration: 4640 nM
For compound 3 the middle estimate is 7.7-fold (0.89 log units) below the measured one; the whole stated range lies below it.
By their numbers in this assay, from the lowest: compound 2; then compound 3; then compound 1.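

Swapping the group on this nitrogen in this assay gives an 11-fold higher number from compound 2 to compound 3 (1.03 log units; beyond the scatter) as the first measured change at this position, showing that the position is far from indifferent to what it carries. The two groups match in heavy-atom count, in having one six-membered aromatic ring of carbon only, in having no hydrogen-bond donors or acceptors and in carrying no net charge, so those counted features alone do not separate compound 2 from compound 3. What differs is that two chlorine atoms leave and a triple bond enters, and no measurement available here explains the step.

On these data alone, whether the chlorine atoms or the ethynyl group matter more remains open. A plain phenyl on the same nitrogen, carrying neither chlorine nor ethynyl, would help to separate the two.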